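Bromo for Methyl on a Hydroxamic Acid Core

The source may hold more compounds than are shown below. What is called first, only, known or untested is meant among the compounds shown, and "the series" means these compounds.

Compound 1, `Cc1cccc(CN2CC=C(CCC(=O)NO)C2=O)c1`: 4720 nM
Compound 2, `CCOc1ccc(CCCN2CC=C(CCC(=O)NO)C2=O)cc1`: 5100 nM
Compound 3, `CC(C)(C)c1ccc(CCCN2CC=C(CCC(=O)NO)C2=O)cc1`: 5100 nM

All three were read in a functional assay on HCT-15 cells (Homo sapiens) for inhibition, read by sulforhodamine B assay; on this read-out lower numbers stand for stronger inhibition of growth and higher numbers for weaker inhibition of growth. Compound 1 holds the lowest of the three numbers, yet compound 2 and compound 3 both lie within the scatter of it, so the data set no order among them. For the measured compounds named here, the single measured step, no change at the digits printed from compound 2 to compound 3 (within the scatter), shows one aromatic substituent traded for another without effect on growth inhibition.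

Compound 4, `O=C(CCC1=CCN(Cc2cccc(Br)c2)C1=O)NO`, differs from compound 1 by bromo in place of methyl on an aromatic carbon. Going by the values given here, no measured step touches this position, and the only aromatic swap on record was flat. The analyst therefore expects no step beyond the scatter in this assay, a change of a 1.0-fold lower number from compound 1 to compound 4 (0.00 log units; within the scatter). Compound 4 is estimated at 4700 nM, ranging from 2000 nM to 11000 nM.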

Compound 4, concentration for 50% growth inhibition: 4720 nM
Compound 4: middle estimate off by 1.0-fold (0.00 log units), on the low side; the measured number falls inside the stated range.
By their numbers in this assay, from the lowest: compounds 1, 4, 2 and 3 (each within the scatter of the next).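

Bromo in place of methyl on an aromatic carbon, meta to a large group, gives no change at the digits printed from compound 1 to compound 4 (within the scatter) in this assay. For the compounds shown here, this is the first step read at this position, which no earlier pair touched, and it adds a second aromatic swap without effect on growth inhibition to the one between compound 2 and compound 3. Nothing on hand explains why this swap leaves the number in place.

With only methyl and bromo read at this aromatic carbon, the compounds shown leave open whether an amine or a carboxylic acid there would also leave growth inhibition in place. They also leave open whether a group as different as a methoxy would do the same on the ring of compound 1.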